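This account rests on a few compounds, and the source may have more. Where it says the series, first, only, none or still open, it means among the compounds named here.

Compound 1 `COc1ccccc1COc1c(-c2ccccc2)c(-c2ccccc2)n2ccc(C#N)cc12` gives "not determined" (no result reported) in an assay for inhibition of Polyunsaturated fatty acid lipoxygenase ALOX15 (Oryctolagus cuniculus) (on this read-out higher numbers stand for weaker inhibition and lower numbers for stronger inhibition), so nothing can be said about where it stands on this read-out. A close relative, compound 2 `N#Cc1ccn2c(-c3ccccc3)c(-c3ccccc3)c(CO)c2c1`, gives 34000 nM in this assay. Compound 3 `N#Cc1ccn2c(-c3ccccc3)c(-c3ccccc3)c(C=O)c2c1` differs from compound 1 in one place: formyl in place of (2-methoxybenzyl)oxy on an aromatic carbon. Going by the values given here, no measured pair shows a step of this kind, so its size and direction in this assay cannot be set from the data; a change beyond the usual scatter cannot be ruled in or out. Compound 3 is expected to give about 20000 nM in this assay, with a range from 6000 nM to 60000 nM, because compound 2 gives 34000 nM and shares nearly its whole structure with compound 3.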

Compound 3, half-maximal inhibitory concentration: 61000 nM
The estimate for compound 3 lay 3.1-fold (0.48 log units) below the measured number; the whole stated range lies below it.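

In this assay, going by these compounds alone, putting formyl in place of hydroxymethyl on this aromatic carbon gives a 1.8-fold higher number from compound 2 to compound 3 (0.25 log units; within the scatter), so this pair gives the first measured step at this position, and that step does not exceed the usual scatter. The step from compound 1 to compound 3 still cannot be read, since compound 1 has no number. Nothing available explains this result.

These two small groups leave open how much larger or different groups at this carbon matter. An amine, a carboxylic acid or a longer chain here could still move the number beyond the scatter.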